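The compounds below may be only part of what the source reports. "The series", "measured", "known", "first", "only" and "open" are said of these compounds alone.

Of the compounds shown here, three built on a shared core have been measured in an assay on CHO cells for displacement of a labelled ligand from adenosine receptor A3 (Homo sapiens), read by scintillation counting, with a stated time of 3 h; on this read-out higher numbers stand for weaker inhibition and lower numbers for stronger inhibition. Compound 1 `Cn1c(-c2ccccc2)nc2c(NC3CCCC3)ncnc21` gives 846 nM in this assay. Compound 2 `CCn1c(-c2ccccc2)nc2c(NC3CCC3)ncnc21` differs from compound 1 in two places at once; in this assay compound 2 gives 84 nM. Compound 3 `Cn1c(-c2cccc(Cl)c2)nc2c(NC3CCCC3)ncnc21` gives 514 nM. Among these three numbers compound 3 stands second highest. Its nearest neighbour is compound 1, and the step of a 1.6-fold lower number from compound 1 to compound 3 (0.22 log units; within the scatter) means the two cannot be told apart. Compound 2 lies furthest away, with a number clearly below that of compound 3. Going by the values given here, compound 2 differs from compound 3 in two places; no single step links them.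

Compound 4 `Cn1c(-c2ccc(O)cc2)nc2c(NC3CCCC3)ncnc21` has not yet been measured. It differs from compound 3 in one place: 4-hydroxyphenyl in place of 3-chlorophenyl on an aromatic carbon. Among the compounds with values here, no measured step involves a hydroxyl group, so none bears directly on this change. Within the data shown here, the only measured step on the same aromatic carbon, a 1.6-fold lower number from compound 1 to compound 3 (0.22 log units; within the scatter), stayed within the scatter. With no closer guide, the expected step in this assay is a 1.4-fold higher number from compound 3 to compound 4 (0.13 log units; within the scatter), with no clear direction beyond the scatter. Compound 4 is therefore estimated to give about 700 nM in this assay, within a range of 200 nM to 2500 nM.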

Compound 4, inhibition constant: 521 nM
Compound 4: middle estimate off by 1.3-fold (0.13 log units), on the high side, and the stated range covers the measured number.
By their numbers in this assay, from the lowest: compound 2; then compounds 3, 4 and 1 (each within the scatter of the next).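

In this assay, replacing 3-chlorophenyl with 4-hydroxyphenyl on this aromatic carbon gives a 1.0-fold higher number from compound 3 to compound 4 (0.01 log units; within the scatter) even though the entering group has a hydrogen-bond donor and acceptor that the leaving group lacks. Hydroxy in place of hydrogen gives a 1.6-fold lower number from compound 1 to compound 4 (0.21 log units; within the scatter) and so, like the earlier chloro step, does not separate its compounds: hydroxy and chloro are now two different groups on this phenyl ring that leave the number within the scatter of the unsubstituted compound 1, and among compounds 1, 3 and 4 nothing goes against this. No separate evidence bears on this result.

Groups of another kind on the phenyl ring, such as an amine or a carboxylic acid, remain untested here, as do 3-hydroxyphenyl and 4-chlorophenyl, which would separate the effect of the group from that of its place on the ring. The lower number of compound 2 also remains unexplained, since its two differences from compound 1 come together and cannot be told apart.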